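The compounds below may be only part of what the source reports. "The series", "measured", "known", "first", "only" and "open" are said of these compounds alone.

Measured so far:
Compound 1, `Nc1ccc(Nc2nc3ccccc3nc2S(=O)(=O)c2ccccc2)cc1`: 8720 nM
Compound 2, `Nc1cccc(Nc2nc3ccccc3nc2S(=O)(=O)c2ccccc2)c1`: 1750 nM
Compound 3, `Nc1ccc(Nc2nc3ccccc3nc2S(=O)(=O)c2ccc(F)cc2)cc1`: 1620 nM

In a functional assay on HL-60 cells (Homo sapiens) for cytotoxicity, read by MTT assay, with a stated time of 72 h (a lower number here means a stronger inhibitor, a higher number a weaker inhibitor), compound 1 gives 8720 nM, the highest of the three numbers. Moving the amino group, (3-aminophenyl in place of 4-aminophenyl on a nitrogen on an aromatic ring), gives a 5.0-fold lower number from compound 1 to compound 2 (0.70 log units; beyond the scatter). Changing the other ring instead, (fluoro in place of hydrogen on an aromatic carbon), gives a 5.4-fold lower number from compound 1 to compound 3 (0.73 log units; beyond the scatter). Compound 2 and compound 3 lie within the usual scatter of each other, so neither can be ranked above the other.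

Compound 4, `Nc1cccc(Nc2nc3ccccc3nc2S(=O)(=O)c2ccc(F)cc2)c1`, is not yet measured. It differs from compound 3 by 3-aminophenyl in place of 4-aminophenyl on a nitrogen on an aromatic ring, the same change that was made from compound 1 to compound 2, at the same place; the cores of compound 3 and compound 1 differ by fluoro in place of hydrogen on an aromatic carbon. Because the earlier change gave a 5.0-fold lower number from compound 1 to compound 2 (0.70 log units; beyond the scatter), a lowering is expected again, though it need not carry over in full on this core. For compound 4 the expected step is a 2.7-fold lower number from compound 3 to compound 4 (0.43 log units; beyond the scatter), resting on that single earlier step. The estimate for compound 4 in this assay is 600 nM, with a likely range from 200 nM to 1800 nM.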

Compound 4, half-maximal inhibitory concentration: 4040 nM
The estimate for compound 4 lay 6.7-fold (0.83 log units) below the measured number; measured number above the stated range.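

The move from 4-aminophenyl to 3-aminophenyl turns around once fluoro is present, giving a 2.5-fold higher number from compound 3 to compound 4 (0.40 log units; beyond the scatter) and so disagreeing with the earlier step: the same change on two cores in this assay, a 5.0-fold lower number (0.70 log units; beyond the scatter) from compound 1 to compound 2 and a 2.5-fold higher number (0.40 log units; beyond the scatter) from compound 3 to compound 4, 12-fold (1.09 log units) apart, beyond the scatter of two such steps.
Fluoro in place of hydrogen also behaves differently on the two cores, now giving a 2.3-fold higher number from compound 2 to compound 4 (0.36 log units; beyond the scatter) rather than a lowering: the same change on two cores in this assay, a 5.4-fold lower number (0.73 log units; beyond the scatter) from compound 1 to compound 3 and a 2.3-fold higher number (0.36 log units; beyond the scatter) from compound 2 to compound 4, 12-fold (1.09 log units) apart, beyond the scatter of two such steps.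
So the two changes do not simply add up in these four compounds, and a step measured on one core cannot be assumed on another, though these data do not show why or whether this holds beyond them.

On these data alone, it remains open whether chloro or methoxy in place of fluoro would show the same reversal. Also open, as far as these compounds go, is how the series would respond to a carboxylic acid in place of the amine.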